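Replacing a pyrrole ketone with a methylphenyl ketone

The source may report more compounds than this note shows. Statements on the series, on what has been measured and on what is new or still open speak of the compounds shown alone.

Measured compounds:
compound 1 `Cn1cccc1C(=O)/C=C/c1ccc2c(c1)B(O)OC2`: > 100000 nM, a limit of the assay
compound 2 `CSc1ccc(C(=O)/C=C/c2ccc3c(c2)B(O)OC3)cc1`: 7400 nM
compound 3 `CCOC(=O)c1ccc(C(=O)/C=C/c2ccc3c(c2)B(O)OC3)cc1`: 12900 nM

Three compounds sharing one core were tested in a toxicity assay on MCF-10A cells (Homo sapiens) for cytotoxicity, read by MTT assay, with a stated time of 48 h; a higher number here means a weaker inhibitor, a lower number a stronger inhibitor. Compound 1 gave no number, only a limit (the limit of > 100000 nM in this assay, at which 1 of the 3 values shown sits). Compound 2 and compound 3, which carry a six-membered carbon ring on the carbonyl, gave numbers: a 1.7-fold higher number from compound 2 to compound 3 (0.24 log units; within the scatter), so the two sit close together.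

Compound 4 `Cc1cccc(C(=O)/C=C/c2ccc3c(c2)B(O)OC3)c1` differs from compound 1 in one place: 3-methylphenyl in place of 1-methyl-1H-pyrrol-2-yl on a carbonyl carbon. Going by the values given here, no measured step covers this exchange of rings. Among the compounds with values here, the only measured step, from compound 2 to compound 3, changes a substituent on a six-membered ring that both already have, so it says nothing about swapping the five-membered ring for a six-membered one. What can be used is that both compounds with a six-membered carbon ring on the carbonyl gave numbers in this assay, while compound 1 with the five-membered ring did not. Compound 4 is therefore expected to give a lower number than the limit of compound 1, a step of about an at least 10-fold lower number from compound 1 to compound 4 (1.00 log units; beyond the scatter). Compound 4 is estimated at 10000 nM, within 3000 nM to 40000 nM.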

Compound 4, half-maximal inhibitory concentration: 15900 nM
Compound 4: the middle estimate sits 1.6-fold (0.20 log units) below what was measured; the range from low to high includes it.
By their numbers in this assay, from the lowest: compounds 2, 3 and 4 (each within the scatter of the next, the first and the last beyond it). At a limit, above all of these: compound 1.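

In this assay, going by these compounds alone, 3-methylphenyl in place of 1-methyl-1H-pyrrol-2-yl on the carbonyl carbon gives an at least 6.2-fold lower number from compound 1 to compound 4 (0.79 log units; beyond the scatter), the first direct reading of a ring exchange at this position. The earlier step changed only a substituent on a six-membered ring that both of its compounds already carried, so it could not speak to the ring itself. The full size of the new step stays unknown, since compound 1 stands at a limit of the assay: the limit of > 100000 nM in this assay, at which 1 of the 4 values shown sits.

The compounds shown leave open whether a plain phenyl without the methyl, or a pyridine ring, on the carbonyl carbon would give a number like that of compound 4. They also leave open how an amine or a carboxylic acid on that ring would read in this assay.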